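This account rests on a few compounds, and the source may have more. Where it says the series, first, only, none or still open, it means among the compounds named here.

Measured so far:
compound 1, `COc1cc2c(Nc3nc4ccc(C(=O)Nc5c(C)cccc5C)cc4s3)ncnc2cc1OCCCN1CCCC1` — in a functional assay on A549 cells (Homo sapiens) for cytotoxicity, read by WST assay, with a stated time of 72 h (on this read-out lower numbers stand for stronger inhibition and higher numbers for weaker inhibition), compound 1 gives 83800 nM
compound 2, `CCN(CC)CCCOc1cc2ncnc(Nc3nc4ccc(C(=O)Nc5c(C)cccc5C)cc4s3)c2cc1OC` — in this assay compound 2 gives > 100000 nM

Where compound 2 stands: its value in this assay is a limit of the assay, not a number, as noted in the limit of > 100000 nM in this assay, at which 1 of the 2 values shown sits. Among the compounds with values here, the one measured step at this position, an at least 1.1-fold higher number from compound 1 to compound 2 (0.07 log units; that floor lies within the scatter), has a floor that lies within the scatter, so the two amines on the saturated chain carbon cannot be told apart on these numbers.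

Compound 3, `COc1cc2c(Nc3nc4ccc(C(=O)Nc5c(C)cccc5C)cc4s3)ncnc2cc1OCCCN1CCCCC1C`, carries the change (2-methylpiperidin-1-yl in place of diethylamino on a saturated chain carbon, three bonds along the chain from an oxygen on an aromatic ring). Within the data shown here, the only measured step bearing on it is an at least 1.1-fold higher number from compound 1 to compound 2 (0.07 log units; that floor lies within the scatter), an exchange of amines at the same place that stayed within the scatter. A step of a size no larger than the scatter is therefore expected from compound 2 to compound 3 in this assay, with no firm direction, namely a number no higher from compound 2 to compound 3 (the limit leaves the size open).

Compound 3 is estimated at 100000 nM in this assay, expected to fall between 50000 nM and 300000 nM, with a real chance that only a limit is reported.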

Compound 3, half-maximal inhibitory concentration: 75700 nM
Compound 3: middle estimate off by 1.3-fold (0.12 log units), on the high side, and the stated range covers the measured number.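

Compound 2 remains a limit of the assay, not a number: the limit of > 100000 nM in this assay, at which 1 of the 3 values shown sits. The new step to compound 3, an at least 1.3-fold lower number from compound 2 to compound 3 (0.12 log units; that floor lies within the scatter), gives only a floor and no firm direction. The step between two measured numbers, a 1.1-fold lower number from compound 1 to compound 3 (0.04 log units; within the scatter), shows that in this assay 2-methylpiperidin-1-yl and pyrrolidin-1-yl cannot be told apart on a saturated chain carbon, three bonds along the chain from an oxygen on an aromatic ring.

All the amines shown at this place leave the series with high numbers, and whether any group here can move the number beyond the scatter stays open. A morpholine, a carboxylic acid or a longer chain at this place would test that, and the shared core may matter more than the amine.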